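Aryl Amide Swap and Cytotoxicity in Epithelial Cells

This account rests on a few compounds, and the source may have more. Where it says the series, first, only, none or still open, it means among the compounds named here.

Of the compounds shown here, three on the shared core have been measured in an ADME assay on HEp-2 cells (Homo sapiens) for cytotoxicity; on this read-out lower numbers stand for higher toxicity in this test and higher numbers for lower toxicity in this test: compound 1 `Cc1ccc(NC(=O)CNS(=O)(=O)c2cccc3cccnc23)c(C)c1`, compound 2 `CC(C)c1ccccc1NC(=O)[C@@H]1CCCN1S(=O)(=O)c1cccc2cccnc12` and compound 3 `Cc1ccc(C(F)(F)F)cc1NC(=O)[C@@H]1CCCN1S(=O)(=O)c1cccc2cccnc12`. For compound 1 the assay reports only a limit, > 50000 nM. Compound 2 gives 29900 nM, the higher of the two actual numbers. The nearest number belongs to compound 3, which gives 4800 nM; that gap lies beyond the usual scatter. Compound 4 `COc1ccc(C)cc1NC(=O)[C@@H]1CCCN1S(=O)(=O)c1cccc2cccnc12` is not yet measured and differs from compound 2 in one place: 2-methoxy-5-methylphenyl in place of 2-isopropylphenyl on an amide-type nitrogen. Going by the values given here, no measured pair differs in a single place, so the change has no direct precedent here. The step from compound 2 to compound 4 is expected to be small, at most modestly toward higher numbers a 1.2-fold higher number from compound 2 to compound 4 (0.07 log units; within the scatter). Compound 4 is estimated at 35000 nM, within 12000 nM to 60000 nM.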

Compound 4, half-maximal cytotoxic concentration: > 50000 nM
Compound 4: a limit, no number (the forecaster's own chance of this, stated with the estimate: 35%); at least 1.4-fold (0.15 log units) between middle value and limit.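

In this assay compound 4 gives only a limit, > 50000 nM. Going by these compounds alone, this is the first single-place change on the shared core, and it reads as an at least 1.6-fold higher number from compound 2 to compound 4 (0.22 log units; that floor lies within the scatter), so replacing 2-isopropylphenyl with 2-methoxy-5-methylphenyl on the amide-type nitrogen shows no move toward lower numbers. The true size of the step cannot be read, as the read-out stops at a limit: the limit of > 50000 nM in this assay, at which 2 of the 4 values shown sit.

On these data alone, it remains open whether a group carrying an amine or a carboxylic acid at this place would give lower numbers.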